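3-Hydroxyphenyl in place of piperidin-4-yl: a tolerability question

A few compounds are considered here, and "the series" means these few. Any claim that something is new, unique, unknown or untested is made for them only; others in the source may bear on it.

Three compounds share one core and differ only in the group on the amide carbonyl. Compound 1 `COc1ccc(-c2cnc(NC(=O)C3CCCC3)n2C)cc1` carries cyclopentyl there, compound 2 `COc1ccc(-c2cnc(NC(=O)c3ccccc3C#N)n2C)cc1` carries 2-cyanophenyl, and compound 3 `COc1ccc(-c2cnc(NC(=O)C3CCNCC3)n2C)cc1` carries piperidin-4-yl. In a toxicity assay on THP-1 cells (Homo sapiens) for inhibition (a lower number here means that less compound is tolerated, a higher number that more compound is tolerated), compound 1 gives only a limit, > 100000 nM. In this assay compound 2 likewise gives a limit, > 100000 nM. In this assay compound 3 also gives a limit, > 100000 nM. Because the limit of > 100000 nM in this assay, at which 3 of the 3 values shown sit, none of the three steps can be read: a step that the two limits leave unreadable from compound 1 to compound 2, a step that the two limits leave unreadable from compound 1 to compound 3 and a step that the two limits leave unreadable from compound 2 to compound 3. Compound 3 therefore stands at the same limit as the other two, with no number of its own.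

Compound 4 `COc1ccc(-c2cnc(NC(=O)c3cccc(O)c3)n2C)cc1` is not yet measured. It differs from compound 3 in one place: 3-hydroxyphenyl in place of piperidin-4-yl on a carbonyl carbon. Among the compounds with values here, no measured step carries this same change, and the three steps that exist are unreadable, so they give neither a size nor a direction. The expectation rests only on the fact that three quite different groups on this carbonyl all sit at the limit, so no step beyond the scatter is expected for a number no higher from compound 3 to compound 4 (the limit leaves the size open). Compound 4 is expected at 100000 nM, within 40000 nM to 250000 nM, and most likely will again be reported only as a limit.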

Compound 4, half-maximal cytotoxic concentration: > 100000 nM
Compound 4: no number, only a limit; the forecaster's own chance of this, stated with the estimate: 80%; the middle value sits exactly at the limit.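

In this assay compound 4 gives > 100000 nM, which is a limit and not a number. The steps to compound 4 from compound 1, compound 2 and compound 3 cannot be read, because all four compounds sit at the same limit: the limit of > 100000 nM in this assay, at which 4 of the 4 values shown sit.

Still open is at what concentration any of these compounds becomes toxic in this assay, and whether the group on the carbonyl changes that concentration.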